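Replacing the phenyl group of compound 1 with a larger heteroaromatic group

The compounds below may be only part of what the source reports. "The series", "measured", "known", "first", "only" and "open" are said of these compounds alone.

Measured compounds:
Compound 1, `CCOC(=O)C1=C(Nc2ccccc2)S/C(=C\c2ccccc2)C1=O`: 20.3%
Compound 2, `CCOC(=O)C1=C(Nc2ccccc2)S/C(=C\c2cc(OC)ccc2OC)C1=O`: 38.1%
Compound 3, `CCOC(=O)C1=C(Nc2ccc([N+](=O)[O-])cc2)S/C(=C\c2ccc[nH]2)C1=O`: 54.9%

Of the compounds shown here, three built on the same core have been tested in a functional assay on JAR cells (Homo sapiens) for inhibition, read by MTT assay, with a stated time of 72 h, tested at 10 uM; on this read-out higher numbers stand for more inhibition at the one concentration tested (going by the name of the read-out) and lower numbers for less inhibition. Compound 1 gives 20.3%, the lowest of the three numbers. Compound 2 lies above it by a margin beyond the scatter, and compound 3, the highest of the three, lies further above it, also beyond the scatter. No pair among these three differs in only one place, so no single change can be tied to a measured step.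

Compound 4, `CCOC(=O)C1=C(Nc2ccccc2)S/C(=C\c2cc3cnccc3[nH]2)C1=O`, has not yet been measured. It differs from compound 1 in one place: a group of 9 heavy atoms (7 carbon, 2 nitrogen; one five-membered aromatic ring with 1 hetero atom, one six-membered aromatic ring with 1 hetero atom) in place of a group of 6 heavy atoms (6 carbon; one six-membered aromatic ring of carbon only), on a double-bonded chain carbon bound to a double-bonded ring carbon. Both other measured compounds exceed compound 1, and compound 3, which also carries a five-membered aromatic ring with a hetero atom at that position, gives 54.9%, though it differs from compound 1 in a second place as well. Compound 4 is therefore expected to give about 36%, within a range from 15% to 60%. The expected step of a number 15.7 percentage points higher from compound 1 to compound 4 (beyond the scatter) is an increase beyond the scatter, but the uncertainty is wide.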

Compound 4, a percentage reported as inhibition, at one concentration (the size of the read-out at that concentration, not a potency): < 10%
Compound 4: no number, only a limit (the forecaster's own chance of this, stated with the estimate: 0%); middle value at least 26 percentage points from the limit.
By their numbers in this assay, from the lowest: compound 1; then compound 2; then compound 3. At a limit, below all of these: compound 4.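

In this assay, putting the group of 9 heavy atoms in place of phenyl, on a double-bonded chain carbon bound to a double-bonded ring carbon, gives a number at least 10.3 percentage points lower from compound 1 to compound 4 (beyond the scatter). Among the compounds shown here, this is the first single change measured at this position, and it shows that a larger group with a five-membered aromatic ring does not by itself bring more inhibition on the core of compound 1. Compound 4 gives < 10%, which is a limit and not a number, so the full size of the step stays unknown: the limit of < 10% in this assay, at which 1 of the 4 values shown sits.

The compounds shown leave open whether the drop goes with the ring nitrogen atoms or with the larger group as a whole. A plain pyrrole ring or an indole in place of the phenyl of compound 1 would separate these two readings.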